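Swapping the Fluorinated Ring of Compound 1

The source may hold more compounds than are shown below. What is called first, only, known or untested is meant among the compounds shown, and "the series" means these compounds.

- compound 1 `COc1ccc(/C=C/C(=O)c2ccccc2-c2ccc(F)cc2)cc1OC`: 440 nM
- compound 2 `COc1ccc(/C=C/C(=O)c2ccccc2-c2ccc(F)cc2)cc1O`: 65 nM
- compound 3 `COc1ccc(/C=C/C(=O)c2ccccc2-c2ccc(F)nc2)cc1OC`: not yet measured

Among the measured compounds shown here, in a functional assay on A549 cells (Homo sapiens) for antiproliferative activity, read by sulforhodamine B assay, with a stated time of 48 h (a higher number here means a weaker inhibitor, a lower number a stronger inhibitor), compound 1 gives 440 nM, the higher of the two numbers so far. For the measured compounds named here, the only measured step, a 6.8-fold lower number from compound 1 to compound 2 (0.83 log units; beyond the scatter), places hydrogen in place of methyl on an oxygen on an aromatic ring. Going by the values given here, that step lies beyond the scatter, but it concerns a different group from the one changed in compound 3. Compound 3 carries 6-fluoropyridin-3-yl in place of 4-fluorophenyl on an aromatic carbon. Among the compounds with values here, no measured step tests this exchange, so the data give no firm direction and no step beyond the scatter is expected. The expected change is a 1.4-fold higher number from compound 1 to compound 3 (0.13 log units; within the scatter). For compound 3 the estimated value in this assay is 600 nM, with an expected range from 200 nM to 1800 nM.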

Compound 3, half-maximal inhibitory concentration: 1200 nM
The estimate for compound 3 lay 2.0-fold (0.30 log units) below the measured number, within the range that was stated.
By their numbers in this assay, from the lowest: compound 2; then compound 1; then compound 3.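

In this assay, the exchange of 4-fluorophenyl for 6-fluoropyridin-3-yl, on an aromatic carbon ortho to a large group, gives a 2.7-fold higher number from compound 1 to compound 3 (0.44 log units; beyond the scatter). Among the compounds shown here, this is the first measured change at this place, and it shows that the number responds to the ring here: the entering ring, with one nitrogen in the ring and one hydrogen-bond acceptor by count, moves it beyond the scatter towards weaker inhibition. Nothing measured explains this rise.

The compounds shown leave open whether the same exchange would have a similar effect on compound 2, which carries the hydroxyl group. They also leave open whether a pyridin-3-yl ring without fluorine, or a 4-chlorophenyl ring, would give a number closer to that of compound 1 or of compound 3.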